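A few compounds are considered here, and "the series" means these few. Any claim that something is new, unique, unknown or untested is made for them only; others in the source may bear on it.

Measured so far in an assay on CHO cells for agonist activity at Free fatty acid receptor 1 (Homo sapiens), read by luminescence, with a stated time of 20 s, in the presence of a further agent that is not named here; a lower number here means that less compound is needed, a higher number that more compound is needed for the effect:
- compound 1, `Cc1ccccc1-c1cccc(COc2ccc([C@H](CC(=O)O)c3nccn3C)cc2)c1`, gives 43 nM
- compound 2, `COc1ccccc1-c1cccc(COc2ccc([C@H](CC(=O)O)c3nccn3C)cc2)c1`, gives 410 nM
- compound 3, `Cn1ccnc1[C@@H](CC(=O)O)c1ccc(OCc2cccc(-c3ccc(Cl)cc3Cl)c2)cc1`, gives 69 nM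

Compound 3 holds the second highest of the three numbers: the step from compound 1 to compound 3 is within the scatter (a 1.6-fold higher number from compound 1 to compound 3 (0.21 log units; within the scatter)), whereas the step from compound 2 to compound 3 lies beyond it (a 5.9-fold lower number from compound 2 to compound 3 (0.77 log units; beyond the scatter)).

Compound 4, `Cc1cc(F)ccc1-c1cccc(COc2ccc([C@H](CC(=O)O)c3nccn3C)cc2)c1`, differs from compound 3 in one place: 4-fluoro-2-methylphenyl in place of 2,4-dichlorophenyl on an aromatic carbon. The step most closely bearing on this change is a 1.6-fold higher number from compound 1 to compound 3 (0.21 log units; within the scatter), which shows that 2-methylphenyl and 2,4-dichlorophenyl gave numbers within the scatter of each other. Compound 4 carries a 2-methylphenyl group with an added fluorine, so no step beyond the scatter is expected, and a 1.5-fold lower number from compound 3 to compound 4 (0.19 log units; within the scatter) is the estimated change. Compound 4 is therefore expected to give about 45 nM, within the range 18 nM to 115 nM.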

Compound 4, half-maximal effective concentration: 59 nM
Compound 4: the middle estimate sits 1.3-fold (0.12 log units) below what was measured, within the range that was stated.
By their numbers in this assay, from the lowest: compounds 1, 4 and 3 (each within the scatter of the next); then compound 2.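

In this assay, for the compounds shown here, adding fluoro to the 2-methylphenyl group moves the number only within the scatter (a 1.4-fold higher number from compound 1 to compound 4 (0.14 log units; within the scatter)), the first direct reading of a single added atom on this ring. 4-Fluoro-2-methylphenyl and 2,4-dichlorophenyl also stay within the scatter of each other (a 1.2-fold lower number from compound 3 to compound 4 (0.07 log units; within the scatter)), while the 2-methoxyphenyl group remains clearly apart from the fluorinated group (a 6.9-fold lower number from compound 2 to compound 4 (0.84 log units; beyond the scatter)). Nothing measured here explains these steps.

On these data alone, whether an amine or a nitrile in place of the fluoro would also stay within the scatter remains open. So does whether a fluoro added to the 2-methoxyphenyl group would alter the number of compound 2.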